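Halogen to trifluoromethoxy on the aryl urea

This account rests on a few compounds, and the source may have more. Where it says the series, first, only, none or still open, it means among the compounds named here.

Measured compounds in a functional assay on CRL2813 cells (Homo sapiens) for cytotoxicity, read by sulforhodamine B assay, with a stated time of 5 days; on this read-out lower numbers stand for stronger inhibition and higher numbers for weaker inhibition:
- compound 1, `O=C(Nc1ccccc1F)N[C@H]1CC[C@H](Oc2ccc(F)cc2)CC1`, 17500 nM
- compound 2, `O=C(Nc1ccccc1Br)N[C@H]1CC[C@H](Oc2ccc(F)cc2)CC1`, 7700 nM
- compound 3, `O=C(Nc1ccccc1Cl)N[C@H]1CC[C@H](Oc2ccc(F)cc2)CC1`, 9100 nM

Compound 3 gives the second highest of the three numbers in this assay. Its nearest neighbour is compound 2, separated by a 1.2-fold higher number from compound 2 to compound 3 (0.07 log units; within the scatter), and its furthest is compound 1, separated by a 1.9-fold lower number from compound 1 to compound 3 (0.28 log units; within the scatter); both separations sit within the scatter. Within the data shown here, the only step that clears the scatter is a 2.3-fold lower number from compound 1 to compound 2 (0.36 log units; beyond the scatter), and even that is modest. Across the three, swapping one halogen for another on this aromatic carbon shifts the number little.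

Compound 4, `O=C(Nc1ccccc1OC(F)(F)F)N[C@H]1CC[C@H](Oc2ccc(F)cc2)CC1`, has not been measured. Its change from compound 3 is trifluoromethoxy in place of chloro on an aromatic carbon. Among the measured compounds shown here, no measured step involves trifluoromethoxy, so the expectation rests on the halogen swaps alone, all of which were small. The step from compound 3 to compound 4 in this assay is therefore expected to be small, in either direction or none beyond the scatter, and is estimated as a 1.2-fold lower number from compound 3 to compound 4 (0.08 log units; within the scatter). Compound 4 is expected to give about 7500 nM, with a range from 3000 nM to 19000 nM.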

Compound 4, half-maximal inhibitory concentration: > 20000 nM
Compound 4 was reported as a limit; the forecaster's own chance of this, stated with the estimate: 5%; middle value at least 2.6-fold (0.42 log units) from the limit.
By their numbers in this assay, from the lowest: compounds 2, 3 and 1 (each within the scatter of the next, the first and the last beyond it). At a limit, above all of these: compound 4.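

In this assay, the halogen swaps on this aromatic carbon moved the number only slightly, whereas trifluoromethoxy in place of chloro gives an at least 2.1-fold higher number from compound 3 to compound 4 (0.34 log units; beyond the scatter) and trifluoromethoxy in place of bromo gives an at least 2.5-fold higher number from compound 2 to compound 4 (0.41 log units; beyond the scatter), so this position is not indifferent to every group placed on it. Going by these compounds, compound 4 is reported only as a limit of the assay, > 20000 nM, not as a number, so both steps are floors and its true distance from the halogen compounds stays unknown: the limit of > 20000 nM in this assay, at which 1 of the 4 values shown sits. Against fluoro, the same change gives an at least 1.1-fold higher number from compound 1 to compound 4 (0.05 log units; that floor lies within the scatter), so on these data compound 4 cannot be set apart from compound 1, and the clear separation holds only against the bromo and chloro compounds.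

Open, on these data alone, is whether methoxy or trifluoromethyl on this same aromatic carbon would stay with the halogen compounds or move with compound 4, and the same holds for an amine or a carboxylic acid there. Also open, as far as these compounds go, is whether the step seen here would persist if the 4-fluorophenoxy group of the shared core were replaced, for example by a plain phenoxy group.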